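The compounds below may be only part of what the source reports. "The series", "measured", "known", "first", "only" and "open" are said of these compounds alone.

Measured so far:
compound 1 `Nc1scc(CN2CCN(c3ccc(Cl)c(C(F)(F)F)c3)CC2)c1C(=O)c1ccc(Cl)cc1`: -2.5%
compound 2 `Nc1scc(CN2CCN(c3ccc(C(F)(F)F)cc3)CC2)c1C(=O)c1cccc(C(F)(F)F)c1`: -12%

In a functional assay on CHO cells with adenosine receptor A1 (Homo sapiens) as the target, read by cAMP accumulation and immunoassay, with a stated time of 6 min, tested at 0.01 uM (on this read-out lower numbers stand for a stronger effect and higher numbers for a weaker effect at the one concentration tested), compound 1 gives -2.5% and compound 2 gives -12%. Compound 1 holds the higher of the two numbers, but its gap to compound 2 lies within the scatter, so the two values show no real difference; both sit close to zero at the single concentration tested.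

Compound 3 `Nc1scc(CN2CCN(c3cccc(F)c3F)CC2)c1C(=O)c1ccc(Cl)cc1` has not been measured. It differs from compound 1 by 2,3-difluorophenyl in place of 4-chloro-3-(trifluoromethyl)phenyl on an amine nitrogen in a ring. For the measured compounds named here, no step between measured compounds covers a change of this kind, so nothing tells how this assay responds to it. With both measured values near zero, the working expectation is that compound 3 stays in the same region. Compound 3 is expected to give about -3% in this assay, within -18% to 12%. This estimate means an expected step of a number 0.5 percentage points lower from compound 1 to compound 3 (within the scatter), none beyond the scatter.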

Compound 3, a percentage reported as activity, at one concentration (the size of the read-out at that concentration, not a potency): -13%
Compound 3: middle estimate off by 10 percentage points, on the high side; the range from low to high includes it.
By their numbers in this assay, from the lowest: compounds 3, 2 and 1 (each within the scatter of the next, the first and the last beyond it).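

In this assay, for the compounds shown here, the aryl group on the amine nitrogen in a ring is the first place with a readable single change: 2,3-difluorophenyl in place of 4-chloro-3-(trifluoromethyl)phenyl gives a number 10.5 percentage points lower from compound 1 to compound 3 (beyond the scatter) while the rest of compound 1 stays fixed. This place therefore has an effect on the read-out, and the smaller aryl group is compatible with a stronger effect at the one concentration tested, though this says nothing of potency. No measurement available here explains the step.

Going by these compounds, with both substituents of compound 1 and both fluorines of compound 3 changed in one step, the contribution of each group remains open. Unsubstituted phenyl or a methoxy group on the same ring could help separate them, and the trend beyond this single pair is unknown.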